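Acylating the Aniline Nitrogen of Compound 1

The compounds below may be only part of what the source reports. "The series", "measured", "known", "first", "only" and "open" are said of these compounds alone.

Measured compounds:
compound 1, `CC1(C)C(=O)NC(c2ccc(N)cc2)c2ccccc21`: 100 mg/kg
compound 2, `Cc1ccc2c(c1)C(c1ccc(N)cc1)NC(=O)C2(C)C`: 300 mg/kg

Of the compounds shown here, two have been measured in a functional assay on the whole organism with Mus musculus as the target, with a stated time of 3 h; a higher number here means that more compound is needed for the effect, a lower number that less compound is needed. Compound 1 has the lowest of the two numbers; compound 2 stands a 3.0-fold higher number from compound 1 to compound 2 (0.48 log units; beyond the scatter). Among the compounds with values here, that single step concerns a methyl in place of hydrogen on an aromatic carbon and is the only comparison available.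

Compound 3, `CC(C)NCC(=O)Nc1ccc(C2NC(=O)C(C)(C)c3ccccc32)cc1`, has not yet been measured in this assay. Its difference from compound 1 is ((isopropylamino)methyl)carbonyl in place of hydrogen on a nitrogen on an aromatic ring. The amino group of compound 1 thus becomes an amide carrying an isopropylamino group.

Within the data shown here, no measured step touches the nitrogen on the aromatic ring, so the one known step, from compound 1 to compound 2, does not bear on this change; it only shows that a small change elsewhere in the shared core moved the number modestly. With nothing to point in either direction, the expectation for compound 3 is a number close to that of compound 1, with a wide range to allow for the uncertainty: no change at the digits printed from compound 1 to compound 3 (within the scatter). Compound 3 is therefore estimated at 100 mg/kg, between 30 mg/kg and 300 mg/kg.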

Compound 3, dose for half-maximal effect: 100 mg/kg
Estimate against measurement, compound 3: no gap at the digits printed; measured number inside the range.
By their numbers in this assay, from the lowest: compounds 1 and 3 (each within the scatter of the next); then compound 2.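

In this assay, within the data shown here, the first look at the nitrogen on an aromatic ring gives no change at the digits printed from compound 1 to compound 3 (within the scatter) even though ((isopropylamino)methyl)carbonyl, with 7 heavy atoms and no ring, stands in place of a single hydrogen atom. Among these compounds, the only earlier step was on an aromatic carbon, where a methyl group gave a 3.0-fold higher number from compound 1 to compound 2 (0.48 log units; beyond the scatter) and so moved the number beyond the scatter, whereas this much larger group on the nitrogen leaves the number within it. Nothing measured here explains why the number stays within the scatter at this nitrogen.

Going by these compounds, one acylated compound says nothing about which part of the group matters, so it stays open whether an acetyl group, a longer chain between the carbonyl and the amine, or a carboxylic acid at the end of the chain would also stay within the scatter in this assay of compound 1. On these data alone, it also stays open whether the methyl group on the aromatic carbon and ((isopropylamino)methyl)carbonyl on the nitrogen would act independently if they were combined in one compound.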